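Heteroaryl Replacement at the Saturated Ring Carbon

This account rests on a few compounds, and the source may have more. Where it says the series, first, only, none or still open, it means among the compounds named here.

Measured compounds:
Compound 1, `COc1cc(N2C(N)=C(C#N)C(c3ccc([N+](=O)[O-])cc3)C3=C2CC(C)(C)CC3=O)cc(OC)c1OC`, 80%
Compound 2, `COc1cc(N2C(N)=C(C#N)C(c3ccc(Cl)cc3Cl)C3=C2CC(C)(C)CC3=O)cc(OC)c1OC`, 100%

Both compounds share one core and were tested in a functional assay on Ehrlich cells (Mus musculus) for cytotoxicity, tested at 100 ug/mL; a higher number here means a stronger effect of the compound at the concentration tested, a lower number a weaker effect. Compound 2 gives 100%, the higher of the two numbers; compound 1 stands lower at 80%, and the gap between the two exceeds the usual scatter. Among the measured compounds shown here, the only measured step, a number 20 percentage points higher from compound 1 to compound 2 (beyond the scatter), changed the aryl group on the saturated ring carbon and gave a modest rise.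

Compound 3, `COc1cc(N2C(N)=C(C#N)C(c3ccc(C)o3)C3=C2CC(C)(C)CC3=O)cc(OC)c1OC`, has not yet been measured. It differs from compound 2 at the same place: 5-methylfuran-2-yl in place of 2,4-dichlorophenyl on a saturated ring carbon. The step from compound 1 to compound 2 is the only one that bears on it, as it also swaps the group on that ring carbon, and it was modest in size. For the measured compounds named here, no measured pair shows a five-membered ring with a hetero atom entering at this position, so the direction is uncertain. Given that compound 2 sits at the top of the range shown, the expected step is a number 15 percentage points lower from compound 2 to compound 3 (beyond the scatter), most likely small or flat, with room only downward. Compound 3 is therefore estimated at 85%, within 60% to 100%.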

Compound 3, a percentage reported as activity, at one concentration (the size of the read-out at that concentration, not a potency): 50%
Beside the measured number, compound 3's estimate is 35 percentage points above it, and the stated range ends above it.
By their numbers in this assay, from the lowest: compound 3; then compound 1; then compound 2.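

In this assay, the 5-methylfuran-2-yl group did not serve as an equal replacement for the phenyl groups on the saturated ring carbon, with a number 50 percentage points lower from compound 2 to compound 3 (beyond the scatter) and, against the 4-nitrophenyl group, a number 30 percentage points lower from compound 1 to compound 3 (beyond the scatter) as the measured outcomes. Both phenyl-bearing compounds stand above compound 3, so the earlier spread between compound 1 and compound 2 did not mark the full range at this carbon, and the position proves more sensitive to the entering group than that single pair could show. No accompanying measurement bears on the origin of this fall.

The compounds shown leave open whether the loss belongs to the furan ring itself or to its methyl group, and an unsubstituted furan-2-yl or a 5-methylthiophen-2-yl group on the same carbon would separate these readings. They also leave open how a six-membered ring containing nitrogen, such as pyridin-3-yl, or an unsubstituted phenyl would stand relative to the two substituted phenyl groups at this position.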